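The source may hold more compounds than are shown below. What is called first, only, known or untested is meant among the compounds shown, and "the series" means these compounds.

Measured so far:
compound 2, `CCC(COc1cccc(C(F)(F)F)c1)OC(=O)Nc1ccccc1`: > 100000 nM in an assay for inhibition of zeta-carotene desaturase, chloroplastic/chromoplastic (Capsicum annuum), using a Dixon plot, with a stated time of 8 h; on this read-out lower numbers stand for stronger inhibition and higher numbers for weaker inhibition
compound 1, `CCC(COc1ccc(Cl)c(Cl)c1)OC(=O)NCc1ccccc1`: > 100000 nM in this assay

The value of compound 2 is a limit of the assay, not a number. The value of compound 1 is likewise a limit. Compound 2 thus stands at the limit of > 100000 nM in this assay, at which 2 of the 2 values shown sit, and no order between the two measured compounds can be read from this. Compound 3, `CCC(COc1cccc(C(F)(F)F)c1)OC(=O)NCc1ccc(Cl)cc1`, is not yet measured. It differs from compound 2 in one place: 4-chlorobenzyl in place of phenyl on an amide-type nitrogen. Compound 1 carries a benzyl group on the same nitrogen, with a different phenoxy part, and also gives only a limit. Going by the values given here, no measured step exists, so the size of the step in this assay cannot be taken from data; nothing in the two limits points to a gain beyond the scatter. Compound 3 is expected to remain around the limit, with an estimate of 150000 nM (range 30000 nM to 500000 nM). The estimated step is a step that the limit leaves unreadable from compound 2 to compound 3.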

Compound 3, half-maximal inhibitory concentration: > 100000 nM
Compound 3 was reported as a limit; the forecaster's own chance of this, stated with the estimate: 75%; the middle value is on the limit's open side.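

In this assay compound 3 gives > 100000 nM as a limit, not a number. Going by these compounds alone, compound 2 also stands at a limit, so no step from compound 2 to compound 3 can be read. The compounds shown leave open which change, if any, on the amide-type nitrogen or the shared core would give a number rather than a limit in this assay for this series.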